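Swapping an Indole for Bromophenyl in a Growth Inhibitor

The source may report more compounds than this note shows. Statements on the series, on what has been measured and on what is new or still open speak of the compounds shown alone.

Measured so far:
compound 1, `Cc1ccc(CS(=O)(=O)/C(=C/c2c[nH]c3ccccc23)C(=O)c2ccc(Cl)cc2)cc1`: 25000 nM
compound 2, `Cc1ccc(S/C(=C/c2ccc(-c3ccccc3)cc2)C(=O)c2ccc(Cl)cc2)cc1`: 50000 nM
compound 3, `O=C(/C(=C\c1ccc(Br)cc1)SCc1ccc(Cl)cc1)c1ccc(Br)cc1`: 1000 nM

These numbers come from a functional assay on DU-145 cells (Homo sapiens) for inhibition, read by trypan blue exclusion, with a stated time of 96 h; a higher number here means a weaker inhibitor of growth, a lower number a stronger inhibitor of growth. Compound 1 gives the second highest of the three; compound 2 sits close enough that the two cannot be told apart, while compound 3 gives a far lower number, well beyond the scatter. Compound 4, `Cc1ccc(CS(=O)(=O)/C(=C/c2ccc(Br)cc2)C(=O)c2ccc(Cl)cc2)cc1`, is not yet measured. It differs from compound 1 by 4-bromophenyl in place of 1H-indol-3-yl on a double-bonded chain carbon bound to a double-bonded chain carbon. Going by the values given here, no measured pair differing in one place exists, so the step can only be guessed. Because compound 3 gives 1000 nM and also carries a 4-bromophenyl, some drop is expected, though its other parts differ too. Compound 4 is estimated at 6000 nM, with a range from 1500 nM to 25000 nM. The expected step is a 4.2-fold lower number from compound 1 to compound 4 (0.62 log units; beyond the scatter).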

Compound 4, concentration for 50% growth inhibition: 25000 nM
Estimate against measurement, compound 4: 4.2-fold (0.62 log units) below, within the range that was stated.
By their numbers in this assay, from the lowest: compound 3; then compounds 1, 4 and 2 (each within the scatter of the next).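

In this assay, putting 4-bromophenyl in place of 1H-indol-3-yl on a double-bonded chain carbon bound to a double-bonded chain carbon gives no change at the digits printed from compound 1 to compound 4 (within the scatter). On this core, then, the second ring and the hydrogen-bond donor of the indole can go without a visible change in growth inhibition. No measurement here explains why the two groups read alike.

As far as these compounds go, whether a carboxylic acid or an amine at this place would move the number remains open. So does whether this swap would also leave the number unchanged on a different core.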